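Swapping methyl for acetyl on a side-chain oxygen

The source may report more compounds than this note shows. Statements on the series, on what has been measured and on what is new or still open speak of the compounds shown alone.

Compound 1 `OCCc1cn(Cc2ccc(Cl)cc2)c2ccccc12`: > 31600 nM (a limit of the assay)
Compound 2 `COCc1cn(Cc2ccc(Cl)cc2)c2ccccc12`: 7940 nM

Among the measured compounds shown here, in a functional assay on T29Kt1 cells (Homo sapiens) for cytotoxicity, read by sulforhodamine B assay, with a stated time of 3 days (on this read-out lower numbers stand for stronger inhibition and higher numbers for weaker inhibition), compound 2 gives 7940 nM, the only exact number so far. Compound 1 is reported only as a limit, > 31600 nM.

Compound 3 `CC(=O)OCc1cn(Cc2ccc(Cl)cc2)c2ccccc12` differs from compound 2 by acetyl in place of methyl on an oxygen on a saturated carbon.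

For the measured compounds named here, one measured step bears on this change: an at least 3.9-fold lower number from compound 1 to compound 2 (0.59 log units; beyond the scatter). It lies beyond the scatter, and its size rests on a limit. That step shows that altering this side chain can shift the number, but it involves no acetyl group. The expectation is therefore modest, with no clear direction. The expected step is a 1.1-fold lower number from compound 2 to compound 3 (0.05 log units; within the scatter), which is estimated to stay within the scatter. Compound 3 is expected at 7000 nM, with an estimated range of 2500 nM to 20000 nM.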

Compound 3, half-maximal inhibitory concentration: 63 nM
For compound 3 the middle estimate is 110-fold (2.05 log units) above the measured one; the measured number lies below the stated range.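

In this assay, the group on this side-chain oxygen matters far more than compound 2 alone could show: acetyl in place of methyl gives a 130-fold lower number from compound 2 to compound 3 (2.10 log units; beyond the scatter), a single swap on an otherwise unchanged structure that brings in a carbonyl. The comparison with the hydroxymethyl compound also points to a large change, with an at least 500-fold lower number from compound 1 to compound 3 (2.70 log units; beyond the scatter). Compound 1 is reported only as a limit, so the size of that step is a lower bound: the limit of > 31600 nM in this assay, at which 1 of the 3 values shown sits.

The compounds shown leave open whether this large step belongs to acetyl alone or extends to other groups on this oxygen, such as propionyl or benzoyl. They also cannot tell whether the oxygen itself is needed, a question that a matching amide, with nitrogen in its place, would address.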